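From fluoro to methylsulfanyl: a small step expected

The source may hold more compounds than are shown below. What is called first, only, known or untested is meant among the compounds shown, and "the series" means these compounds.

In a functional assay on MDA-MB-231 cells (Homo sapiens) for antiproliferative activity, read by MTT assay, with a stated time of 72 h (a lower number here means a stronger inhibitor, a higher number a weaker inhibitor), compound 1 `O=C(CCc1cccc2c1B(O)OC2)Nc1ccccc1` gives 230 nM as its half-maximal inhibitory concentration. Compound 2 `O=C(CCc1cccc2c1B(O)OC2)Nc1cccc(-c2ccc(F)cc2)c1` gives 250 nM on the same read-out, so the two compounds sit within the scatter of each other.

Compound 3 `CSc1ccc(-c2cccc(NC(=O)CCc3cccc4c3B(O)OC4)c2)cc1` has not yet been measured. It differs from compound 2 in one place: methylsulfanyl in place of fluoro on an aromatic carbon. Going by the values given here, only one measured step bears on this swap. The step of a 1.1-fold higher number from compound 1 to compound 2 (0.04 log units; within the scatter) put a 4-fluorophenyl in place of hydrogen on an aromatic carbon, and the number stayed inside the scatter. Among the compounds with values here, no compound carrying methylsulfanyl has a measured value yet, so this evidence is indirect. With that single step as the guide, no change beyond the scatter is expected in this assay for the swap. The estimated step is no change at the digits printed from compound 2 to compound 3 (within the scatter) and no direction is favoured. Compound 3 is expected near 250 nM (estimated range 100 nM to 600 nM).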

Compound 3, half-maximal inhibitory concentration: 140 nM
The estimate for compound 3 lay 1.8-fold (0.25 log units) above the measured number; low and high end bracket the measured number.
By their numbers in this assay, from the lowest: compounds 3, 1 and 2 (each within the scatter of the next).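

In this assay the swap gives a 1.8-fold lower number from compound 2 to compound 3 (0.25 log units; within the scatter) and so shows that this carbon, para to a large group, accepts methylsulfanyl, with its sulfur and carbon, in place of a single fluorine without a shift beyond the scatter. Measured against compound 1, which lacks the added ring altogether, the whole 4-(methylsulfanyl)phenyl group gives a 1.6-fold lower number from compound 1 to compound 3 (0.22 log units; within the scatter) and also stays within the scatter, so two different groups on the added ring now leave the number where the bare core has it. Nothing measured alongside these compounds speaks to what lies behind these numbers, and the small differences among them call for no explanation of their own.

All three compounds leave open whether any group at this position can move the number beyond the scatter, in either direction, since an amine or a carboxylic acid on the same carbon would be a far sharper test than the two groups shown. A longer chain on the sulfur, such as ethylsulfanyl or butylsulfanyl, would likewise show how much more bulk this position accepts.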